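This account rests on a few compounds, and the source may have more. Where it says the series, first, only, none or still open, it means among the compounds named here.

Measured so far in a physicochemical assay for solubility, read by LC-MS, in phosphate buffer, with a stated time of 24 h, at pH 7.4; a lower number here means a less soluble compound, a higher number a more soluble compound:
- compound 1 `CC(=O)N1CCC(c2cnc(NCc3c(F)ccc4c3CCO4)c3cn[nH]c(=O)c23)CC1`: < 2000 nM
- compound 2 `Cc1ncccc1-c1cnc(NCc2c(F)ccc3c2CCO3)c2cn[nH]c(=O)c12`: < 2000 nM

Neither entry is a number; each is a limit of the assay. Compound 2 is therefore known only through its limit of < 2000 nM.

The next compound is compound 3 `CN(c1ccn(C)n1)c1cnc(NCc2c(F)ccc3c2CCO3)c2cn[nH]c(=O)c12`, with the change (methyl(1-methyl-1H-pyrazol-3-yl)amino in place of 2-methylpyridin-3-yl on an aromatic carbon). The group sits on the same aromatic carbon, para to a large group.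

Going by the values given here, the only measured step at this place is a step that the two limits leave unreadable from compound 1 to compound 2, and it gives no size to carry over. The evidence amounts to one observation: the limit of < 2000 nM in this assay, at which 2 of the 2 values shown sit. In this assay no step in either direction is expected beyond the scatter. The expected step is a step that the limit leaves unreadable from compound 2 to compound 3. For compound 3 the estimated value is 1500 nM, with an expected range of 400 nM to 6000 nM.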

Compound 3, solubility: 12000 nM
Compound 3: middle estimate off by 8.0-fold (0.90 log units), on the low side; measured number above the stated range.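

In this assay, going by these compounds alone, methyl(1-methyl-1H-pyrazol-3-yl)amino on this aromatic carbon, para to a large group, gives the first reading here that is a number rather than a limit, with an at least 6.0-fold higher number from compound 2 to compound 3 (0.77 log units; beyond the scatter) and an at least 6.0-fold higher number from compound 1 to compound 3 (0.77 log units; beyond the scatter). The read-out at this place therefore moves with the group held there, which the earlier pair could not show, as the step between compound 1 and compound 2 cannot be read. Both steps give only a minimum size, as each starts from a limit: the limit of < 2000 nM in this assay, at which 2 of the 3 values shown sit.

The compounds shown do not separate the amino link from the five-membered aromatic ring, as the two enter together in compound 3. A simple amine such as dimethylamino or morpholine on this carbon would test the amino link without that ring.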